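Swapping a Methyl for Methoxy on the Fused Ring

This account rests on a few compounds, and the source may have more. Where it says the series, first, only, none or still open, it means among the compounds named here.

For the measured compounds named here, compound 1 `COc1ccc(S(=O)(=O)c2cnc3ccc(C)cc3c2N2CCC(C)CC2)cc1` is one of two compounds measured in an assay on isolated protein for displacement of a labelled ligand from metabotropic glutamate receptor 5 (Homo sapiens), with a stated time of 60 min, tested at 1 uM (on this read-out higher numbers stand for more inhibition at the one concentration tested (going by the name of the read-out) and lower numbers for less inhibition), and in this assay compound 1 gives 62%. Compound 2 `Cc1ccc2ncc(S(=O)(=O)c3ccc(F)cc3)c(N3CCC(C)CC3)c2c1` gives 90%, and the step of a number 28 percentage points higher from compound 1 to compound 2 (beyond the scatter) follows fluoro in place of methoxy on an aromatic carbon, leaving compound 1 the lowest of the two numbers. Compound 3 `COc1ccc(S(=O)(=O)c2cnc3ccc(OC)cc3c2N2CCC(C)CC2)cc1` differs from compound 1 by methoxy in place of methyl on an aromatic carbon. Going by the values given here, no measured step involves this change, so no step beyond the scatter is expected, a number 2 percentage points lower from compound 1 to compound 3 (within the scatter). Compound 3 is therefore estimated at 60%, within 35% to 85%.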

Compound 3, a percentage reported as inhibition, at one concentration (the size of the read-out at that concentration, not a potency): 41%
The estimate for compound 3 lay 19 percentage points above the measured number; the measured number falls inside the stated range.
By their numbers in this assay, from the lowest: compound 3; then compound 1; then compound 2.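

At this aromatic carbon of the shared core, the group matters in this assay: methoxy in place of methyl gives a number 21 percentage points lower from compound 1 to compound 3 (beyond the scatter). For the compounds shown here, the earlier step changed a different place, so this is the first sign that this carbon also affects the read-out. No available evidence explains the drop.

Going by these compounds, it remains open whether a chloro group or an amine at this carbon would keep, raise or lower the number. Also open, on these data alone, is whether methoxy here would lower it in the same way with fluoro on the other aromatic ring.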